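The compounds below may be only part of what the source reports. "The series", "measured", "known", "first", "only" and "open" are said of these compounds alone.

Measured compounds and their values:

compound 1 `CCCc1ccc(NC2=CC(=O)c3c(nc4n3[C@H]3OC[C@@H](O)[C@H]3OC4)C2=O)cc1` — > 4000 nM
compound 2 `COc1cccc(NC2=CC(=O)c3nc4n(c3C2=O)[C@H]2OC[C@@H](O)[C@H]2OC4)c1` — > 4000 nM
compound 3 `CCOc1ccccc1NC1=CC(=O)c2c(nc3n2[C@H]2OC[C@@H](O)[C@H]2OC3)C1=O` — > 4000 nM

The measurement here is a functional assay on MCF7 cells (Homo sapiens) for inhibition, read by sulforhodamine B assay; on this read-out higher numbers stand for weaker inhibition and lower numbers for stronger inhibition. In this assay compound 2 gives > 4000 nM, which is a limit of the assay rather than a number. The same is true of compound 1 and of compound 3: each of their values is also a limit. Compound 2 therefore stands where every measured compound stands, at the limit, so nothing among the shown numbers sets it apart.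

The compound not yet measured is compound 4 `CCOc1ccccc1NC1=CC(=O)c2nc3n(c2C1=O)[C@H]1OC[C@@H](O)[C@H]1OC3`. It keeps the core of compound 2 and changes only the group on the amine nitrogen: 2-ethoxyphenyl in place of 3-methoxyphenyl on an amine nitrogen.

One measured step resembles this change: a step that the two limits leave unreadable from compound 1 to compound 3. Because both of those values are limits, the size of that step cannot be read. Beyond it, the only evidence is the limit of > 4000 nM in this assay, at which 3 of the 3 values shown sit. With all three values at the limit and no readable step, there is no ground to expect a move in either direction beyond the scatter; the most likely outcome is that compound 4 also ends at the limit.

The estimate for compound 4 in this assay is 6000 nM, with a range from 2500 nM to 20000 nM, which corresponds to an expected step that the limit leaves unreadable from compound 2 to compound 4.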

Compound 4, half-maximal inhibitory concentration: > 4000 nM
Compound 4: only a limit was reported; the forecaster's own chance of this, stated with the estimate: 80%; the middle value lies beyond the limit too.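

In this assay compound 4 gives > 4000 nM, which is a limit of the assay and not a number. Among the compounds shown here, compound 2 also sits at a limit, so no step from it to compound 4 can be read. The compounds shown leave open how far each lies beyond the limit, and whether any group on the amine nitrogen would give a readable value.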